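The compounds below may be only part of what the source reports. "The series", "measured", "known", "first", "only" and "open" are said of these compounds alone.

Three compounds that share a core, and a fourth built on the same core, make up this set. Compound 2 `Cc1c(OCCCCOc2ccccc2C(=O)O)ccc(C(=O)CC(C)C)c1C` and compound 3 `Cc1c(OCCCCOc2ccccc2C(=O)O)ccc(C(=O)CC(C)C)c1O` differ in the core itself, where the difference is methyl in place of hydroxy on an aromatic carbon. Compound 1 `COC(=O)c1ccc(OCCCCOc2ccc(C(=O)CC(C)C)c(O)c2C)cc1` is built on the core of compound 3, and compound 4 `COC(=O)c1ccc(OCCCCOc2ccc(C(=O)CC(C)C)c(C)c2C)cc1`, not yet measured, is built on the core of compound 2.

In an assay on HEK293 cells for positive allosteric modulation of metabotropic glutamate receptor 3 (Rattus norvegicus), read by thallium flux, with a stated time of 2.5 min (on this read-out higher numbers stand for larger maximal responses and lower numbers for smaller maximal responses), compound 2 gives 30.7%. In this assay compound 3 gives 28.1%, and compound 1 gives 22.7%. Between the two measured cores the step is a number 2.6 percentage points lower from compound 2 to compound 3 (within the scatter). The change 4-(methoxycarbonyl)phenyl in place of 2-carboxyphenyl on an oxygen on a saturated carbon gives the step of a number 5.4 percentage points lower from compound 3 to compound 1 (within the scatter).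

The same change, (4-(methoxycarbonyl)phenyl in place of 2-carboxyphenyl on an oxygen on a saturated carbon), is made once more, from compound 2 to compound 4, at a place described in the same words. Because the earlier step of a number 5.4 percentage points lower from compound 3 to compound 1 (within the scatter) stayed within the scatter, the step from compound 2 to compound 4 is expected to be of similar size, about a number 5.7 percentage points lower from compound 2 to compound 4 (within the scatter). Compound 4 is therefore estimated to reach 25% in this assay, most likely between 17% and 33%.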

Compound 4, largest response reached (reported as percent of maximum), in percent of the reference or control that the assay uses: 27.3%
Beside the measured number, compound 4's estimate is 2.3 percentage points below it, within the range that was stated.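

In this assay, putting 4-(methoxycarbonyl)phenyl in place of 2-carboxyphenyl gives a number 3.4 percentage points lower from compound 2 to compound 4 (within the scatter), and this step agrees with the one seen on the other core: the same change on two cores in this assay, a number 5.4 percentage points lower (within the scatter) from compound 3 to compound 1 and a number 3.4 percentage points lower (within the scatter) from compound 2 to compound 4, 2 percentage points apart, within the scatter of two such steps. Putting methyl in place of hydroxy gives a number 4.6 percentage points higher from compound 1 to compound 4 (within the scatter), and this step, read in the opposite direction, agrees with its earlier counterpart in the same way: the same change on two cores in this assay, a number 2.6 percentage points lower (within the scatter) from compound 2 to compound 3 and a number 4.6 percentage points lower (within the scatter) from compound 4 to compound 1, 2 percentage points apart, within the scatter of two such steps. Within these four compounds, both changes therefore carry from one core to the other without a detectable difference, but every step lies within the scatter, so this does not show that either change truly alters the response or that the agreement would hold on further cores.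

The compounds shown leave open whether a longer chain on the oxygen, or an amine in place of the hydroxy, would move the largest response beyond the scatter. They also leave open what a carboxylic acid in place of the ester on the 4-(methoxycarbonyl)phenyl group would do.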